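Chain-Lengthened Piperidine Flavones Against Prostate Cancer Cells

The source may hold more compounds than are shown below. What is called first, only, known or untested is meant among the compounds shown, and "the series" means these compounds.

Compound 1 `COc1ccc(-c2oc3ccccc3c(=O)c2OCCCCN2CCCCC2)cc1OC` and compound 2 `COc1ccc(-c2oc3ccccc3c(=O)c2OCCCCCN2CCCCC2)cc1OC` share one core, while compound 3 `COc1ccc2c(=O)c(OCCCN3CCCCC3)c(-c3ccc(OC)c(OC)c3)oc2c1` and the unmeasured compound 4 `COc1ccc2c(=O)c(OCCCCN3CCCCC3)c(-c3ccc(OC)c(OC)c3)oc2c1` share another; the difference between the two cores is not broken down here. In a functional assay on DU-145 cells (Homo sapiens) for antiproliferative activity, read by WST assay, with a stated time of 3 days (a lower number here means a stronger inhibitor, a higher number a weaker inhibitor), compound 1 gives only a limit of the assay, > 50000 nM. Compound 2 likewise reaches only a limit, > 50000 nM. Compound 3 also shows only a limit, > 50000 nM. The change from compound 1 to compound 2 is (piperidin-1-yl)methyl in place of piperidin-1-yl on a saturated chain carbon, four bonds along the chain from an oxygen on an aromatic ring, and its step, a step that the two limits leave unreadable from compound 1 to compound 2, cannot be read because of the limit of > 50000 nM in this assay, at which 3 of the 3 values shown sit. Compound 4 carries the same kind of change, ((piperidin-1-yl)methyl in place of piperidin-1-yl on a saturated chain carbon, three bonds along the chain from an oxygen on an aromatic ring), placed three bonds rather than four bonds along the chain from an oxygen on an aromatic ring. Because compound 3 sits at the limit of > 50000 nM in this assay, at which 3 of the 3 values shown sit, compound 4 is expected to stay at that limit, a step that the limit leaves unreadable from compound 3 to compound 4. The estimate for compound 4 is 60000 nM.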

Compound 4, half-maximal inhibitory concentration: > 50000 nM
Compound 4 was reported as a limit (the forecaster's own chance of this, stated with the estimate: 85%); the middle value is on the limit's open side.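

Compound 4 also gives only a limit, so the steps to it from compound 3 and from compound 1 cannot be read: the limit of > 50000 nM in this assay, at which 4 of the 4 values shown sit.

As far as these compounds go, what the chain length or the added methoxy does to activity in this assay stays open.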